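Swapping Nitrile for Chloro on a Fluorinated Aryl Ring

The source may report more compounds than this note shows. Statements on the series, on what has been measured and on what is new or still open speak of the compounds shown alone.

Measured so far:
compound 1 `Cc1cc(C(=O)O)c(C)n1-c1cccc(C#N)c1F`, 630 nM
compound 2 `Cc1cc(C(=O)O)c(C)n1-c1cccc(C#N)c1`, 3100 nM

Both compounds were tested in an assay on cells for inhibition of Palmitoleoyl-protein carboxylesterase NOTUM variant C330S (Homo sapiens), read by fluorescence, with a stated time of 40 min; on this read-out lower numbers stand for stronger inhibition and higher numbers for weaker inhibition. Among the two numbers available, compound 1 gives the lower one, with compound 2 separated by the step of a 4.9-fold higher number from compound 1 to compound 2 (0.69 log units; beyond the scatter), a change that removes the fluoro group while the cyano group stays in place.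

Compound 3 `Cc1cc(C(=O)O)c(C)n1-c1cccc(Cl)c1F` keeps the fluoro group and the shared core but carries a different substituent: chloro in place of cyano on an aromatic carbon, sitting ortho to a fluoro group and meta to a large group. Among the compounds with values here, no measured step exchanges the cyano group for anything else, so the only measured step, the one from compound 1 to compound 2, concerns a group that is unchanged here and gives no direct guide to the size or direction of this move.

For compound 3 in this assay the expected value is 800 nM, with a range from 200 nM to 3200 nM, which is expected to mean a step of a 1.3-fold higher number from compound 1 to compound 3 (0.10 log units; within the scatter) from compound 1.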

Compound 3, half-maximal inhibitory concentration: 380 nM
Compound 3: middle estimate off by 2.1-fold (0.32 log units), on the high side; low and high end bracket the measured number.
By their numbers in this assay, from the lowest: compounds 3 and 1 (each within the scatter of the next); then compound 2.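

In this assay the step of a 1.7-fold lower number from compound 1 to compound 3 (0.22 log units; within the scatter) shows that this position on the aromatic ring, ortho to a fluoro group and meta to a large group, accepts chloro in place of cyano, since compound 1 and compound 3 cannot be told apart. The nitrile is therefore not needed here for a number in this range, even though chloro brings one heavy atom and no hydrogen-bond acceptor where cyano brings two heavy atoms and one acceptor. Nothing measured explains why the two groups read alike.

On these data alone, whether a methyl, methoxy or bromo group would also be accepted at this position stays open. Within the data shown here, it is also open whether the fluoro group matters as much beside chloro as in the nitrile pair, where the step of a 4.9-fold higher number from compound 1 to compound 2 (0.69 log units; beyond the scatter) is the only guide.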